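A few compounds are considered here, and "the series" means these few. Any claim that something is new, unique, unknown or untested is made for them only; others in the source may bear on it.

In a functional assay on SiHa cells (Homo sapiens) for antiproliferative activity, read by CCK-8 assay, with a stated time of 72 h (a higher number here means a weaker inhibitor, a lower number a stronger inhibitor), compound 2 `COc1ccc(-c2cncnc2-c2cc(OC)c(OC)c(OC)c2)nc1` gives 1750 nM and compound 1 `CCSc1ccc(-c2cncnc2-c2cc(OC)c(OC)c(OC)c2)cc1` gives 1030 nM, so these two numbers lie within the scatter of each other. The next structure is compound 3 `COc1cc(-c2ncncc2-c2ccc(Br)cc2)cc(OC)c1OC`, which has this change: 4-bromophenyl in place of 5-methoxypyridin-2-yl on an aromatic carbon. Within the data shown here, only one measured step bears on it, a swap of groups at the same place on the shared core: a 1.7-fold higher number from compound 1 to compound 2 (0.23 log units; within the scatter). That single step stayed within the scatter, so no step beyond the scatter is expected here, and the expected step is a 1.8-fold lower number from compound 2 to compound 3 (0.24 log units; within the scatter). Compound 3 is estimated at 1000 nM, with an expected range from 300 nM to 3000 nM.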

Compound 3, half-maximal inhibitory concentration: 2960 nM
The estimate for compound 3 lay 3.0-fold (0.47 log units) below the measured number; the range from low to high includes it.
By their numbers in this assay, from the lowest: compounds 1, 2 and 3 (each within the scatter of the next, the first and the last beyond it).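

In this assay, 4-bromophenyl, with no hydrogen-bond acceptors, and 5-methoxypyridin-2-yl, with its acceptors, cannot be told apart at this position (a 1.7-fold higher number from compound 2 to compound 3 (0.23 log units; within the scatter)). Among these compounds, the first step beyond the scatter here comes with bromo in place of ethylsulfanyl (a 2.9-fold higher number from compound 1 to compound 3 (0.46 log units; beyond the scatter)), so a change on the outer ring can shift the number, though only modestly. Nothing measured here explains that difference. Still open, going by these compounds, is how an amine or a carboxylic acid on this ring would read, and whether any group at this position can bring a much lower number.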